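A second fluorine on the amide-bearing aryl ring

The source may report more compounds than this note shows. Statements on the series, on what has been measured and on what is new or still open speak of the compounds shown alone.

Of the compounds shown here, three built on one shared core have been measured in an assay on membranes from striatum (strain Sprague-Dawley) for displacement of a labelled ligand from sodium-dependent dopamine transporter (Rattus norvegicus), read by scintillation counting, with a stated time of 120 min; a higher number here means a weaker inhibitor, a lower number a stronger inhibitor. Compound 1 `Fc1ccc(C(SCCNC2CCN(Cc3ccccc3)CC2)c2ccc(F)cc2)cc1` gives 32.9 nM, compound 2 `Fc1ccc(C(SCCNC2CCN(Cc3ccc(Cl)cc3)CC2)c2ccc(F)cc2)cc1` gives 39.6 nM, and compound 3 `O=C(c1ccccc1F)N1CCC(NCCSC(c2ccc(F)cc2)c2ccc(F)cc2)CC1` gives 46.1 nM, the highest of the three numbers, although a 1.4-fold higher number from compound 1 to compound 3 (0.15 log units; within the scatter) and a 1.2-fold higher number from compound 2 to compound 3 (0.07 log units; within the scatter) both remain within the scatter. Compound 4 `O=C(c1ccc(F)cc1F)N1CCC(NCCSC(c2ccc(F)cc2)c2ccc(F)cc2)CC1` differs from compound 3 by fluoro in place of hydrogen on an aromatic carbon. Within the data shown here, the nearest precedent among the measured steps is a 1.2-fold higher number from compound 1 to compound 2 (0.08 log units; within the scatter), a comparable kind of change, which moved the number by nothing beyond the scatter. On that basis no step beyond the scatter is expected here. Compound 4 is therefore estimated at 50 nM, with a range from 20 nM to 125 nM. The expected step is a 1.1-fold higher number from compound 3 to compound 4 (0.04 log units; within the scatter).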

Compound 4, inhibition constant: 30 nM
Beside the measured number, compound 4's estimate is 1.7-fold (0.22 log units) above it; the range from low to high includes it.
By their numbers in this assay, from the lowest: compounds 4, 1, 2 and 3 (each within the scatter of the next).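

In this assay, fluoro in place of hydrogen on the aromatic carbon para to a large group gives a 1.5-fold lower number from compound 3 to compound 4 (0.19 log units; within the scatter) as its step, so this position accepts a second fluoro with no shift beyond the scatter. The (2,4-difluorophenyl)carbonyl group also stays level with both benzyl-type groups, with a 1.3-fold lower number from compound 2 to compound 4 (0.12 log units; within the scatter) and a 1.1-fold lower number from compound 1 to compound 4 (0.04 log units; within the scatter) as its steps. Nothing at hand accounts for these small steps. Open, on these data alone, is whether a chloro, a methoxy or a nitrile at this position would move the number beyond the scatter.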